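The compounds below may be only part of what the source reports. "The series", "measured", "known", "first", "only" and "open" are said of these compounds alone.

Compound 1 `O=C(NC(=S)Nc1ccc(Cl)c(-c2nc3ccccc3[nH]2)c1)c1ccc(OCc2ccc(C(F)(F)F)cc2)cc1` gives 7830 nM in a functional assay on MNK45 cells (Homo sapiens) for inhibition, read by MTT assay, with a stated time of 48 h; a higher number here means a weaker inhibitor, a lower number a stronger inhibitor. Going by the values given here, compound 2 `O=C(NC(=S)Nc1ccc(Cl)c(-c2nc3ccccc3[nH]2)c1)c1ccc(OCc2ccc(Cl)c(Cl)c2)cc1` gives 4600 nM in this assay, and the only step measured within the set so far is a 1.7-fold lower number from compound 1 to compound 2 (0.23 log units; within the scatter). Compound 3 `Cc1ccc(NC(=O)NC(=O)c2ccc(OCc3ccc(C(F)(F)F)cc3)cc2)cc1-c1nc2ccccc2[nH]1` gives 16800 nM in this assay; this is the highest of the three numbers, and its gaps to compound 1 and to compound 2 are both beyond the scatter, so compound 3 is the weakest inhibitor measured so far. Compound 4 `Cc1ccc(NC(=O)NC(=O)c2ccc(OCc3ccc(Cl)cc3Cl)cc2)cc1-c1nc2ccccc2[nH]1` is not yet measured. It differs from compound 3 in one place: 2,4-dichlorophenyl in place of 4-(trifluoromethyl)phenyl on a saturated chain carbon bound to an oxygen on an aromatic ring. Among the compounds with values here, the one measured step that bears on this is the one between compound 1 and compound 2, where a dichlorophenyl replaced the same 4-(trifluoromethyl)phenyl at the same place and the number stayed within the scatter. The present change carries the two chlorines in a different pattern and sits on a different shared core, so that step is only a loose guide. No movement beyond the scatter is expected, and the step of a 1.4-fold lower number from compound 3 to compound 4 (0.15 log units; within the scatter) is the estimated outcome. Compound 4 is therefore expected to give about 12000 nM in this assay, within a range from 5000 nM to 30000 nM.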

Compound 4, half-maximal inhibitory concentration: 2550 nM
Estimate against measurement, compound 4: 4.7-fold (0.67 log units) above; the measured number lies below the stated range.
By their numbers in this assay, from the lowest: compounds 4, 2 and 1 (each within the scatter of the next, the first and the last beyond it); then compound 3.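

In this assay, going by these compounds alone, the place on a saturated chain carbon bound to an oxygen on an aromatic ring responds to exchange of the 4-(trifluoromethyl)phenyl group: the change to 2,4-dichlorophenyl gives a 6.6-fold lower number from compound 3 to compound 4 (0.82 log units; beyond the scatter), the first step to lie beyond the scatter at this place. The exchange of the same group for 3,4-dichlorophenyl on the core of compound 1 gave only a 1.7-fold lower number from compound 1 to compound 2 (0.23 log units; within the scatter), so a dichlorophenyl group in place of 4-(trifluoromethyl)phenyl does not move the number to the same degree in both settings, and the two steps differ in both the chlorine pattern and the core. No measurement on hand speaks to the origin of this step.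

Open, going by these compounds, is whether the larger step belongs to the 2,4-dichlorophenyl group itself or to the core of compound 3, a question that 3,4-dichlorophenyl on that core and 2,4-dichlorophenyl on the core of compound 1 would settle. Also open, on these data alone, is how this place responds to a group of another kind, such as a 4-chlorophenyl, a pyridine ring or a carboxylic acid.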